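A few compounds are considered here, and "the series" means these few. Any claim that something is new, unique, unknown or untested is made for them only; others in the source may bear on it.

Measured so far:
compound 1 `c1cncc(N2CC3CC2CN3)c1` — 0.3 nM
compound 2 `CN1CCCN(c2cncc(-c3cc(CCO)no3)c2)CC1` — 46.3 nM

In an assay on a protein complex for displacement of a labelled ligand from Neuronal acetylcholine receptor; alpha2/beta2 (Rattus norvegicus), read by scintillation counting (on this read-out higher numbers stand for weaker inhibition and lower numbers for stronger inhibition), compound 1 gives 0.3 nM and compound 2 gives 46.3 nM. Among the measured compounds shown here, compound 2 therefore stands highest of the two numbers, far above compound 1; the gap between them lies beyond the usual scatter, but as the two structures differ in more than one place, the pair shows only its two values and no single step.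

Compound 3 `OCCc1cc(-c2cncc(N3CCCNCC3)c2)on1` has not yet been measured. It differs from compound 2 in one place: hydrogen in place of methyl on an amine nitrogen in a ring. For the measured compounds named here, no measured pair of this series shows such a change, so its size is open. The expectation is a small step from compound 2 to compound 3 toward a lower number, estimated as a 2.3-fold lower number from compound 2 to compound 3 (0.36 log units; beyond the scatter), which may well fall within the scatter. Compound 3 is thus expected to give about 20 nM, in the range 5 nM to 80 nM.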

Compound 3, inhibition constant: 0.8 nM
Beside the measured number, compound 3's estimate is 25-fold (1.40 log units) above it; measured number below the stated range.
By their numbers in this assay, from the lowest: compound 1; then compound 3; then compound 2.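

In this assay, among the compounds shown here, hydrogen in place of methyl on the amine nitrogen of the seven-membered non-aromatic ring gives a 58-fold lower number from compound 2 to compound 3 (1.76 log units; beyond the scatter) and is the first single-place step available. It shows that this nitrogen, three ring bonds from the ring atom that bears a large group, is a sensitive position: the loss of one carbon, with no ring, hydrogen-bond donor or acceptor counted in the leaving group, is enough for a large step beyond the scatter. Nothing measured here accounts for the size of this step.

The two end points, hydrogen and methyl, do not show how an ethyl group, a longer chain or an acetyl group on this nitrogen would read. Going by these compounds, whether the same change gives a step of similar size on other receptor complexes, or with another group in place of the rest of compound 3, also remains open.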